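Morpholinyl carbamate to benzoyl on a hydroxamate series

The source may report more compounds than this note shows. Statements on the series, on what has been measured and on what is new or still open speak of the compounds shown alone.

Measured compounds:
Compound 1, `O=C(/C=C/c1ccccc1OC(=O)c1ccccc1)NOC(=O)N1CCOCC1`, gives 25200 nM in a functional assay on A549 cells (Homo sapiens) for inhibition, read by ELISA, with a stated time of 24 h; on this read-out higher numbers stand for weaker inhibition of growth and lower numbers for stronger inhibition of growth.
Compound 2, `O=C(/C=C/c1ccccc1O)NO`, gives 55200 nM in this assay.

Two compounds of this series have been run so far. Compound 1 stands lowest of the two numbers; compound 2 is its nearest neighbour, with a higher number, and the gap between the two lies beyond the usual scatter of this assay. Going by the values given here, no pair that differs in a single place has been measured, so no single step size is known from the data themselves.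

The next compound, compound 3, `O=C(/C=C/c1ccccc1OC(=O)c1ccccc1)NOC(=O)c1ccccc1`, differs from compound 1 in one place: phenyl in place of morpholin-4-yl on a carbonyl carbon. The rest of the molecule, including the benzoyloxy group on the shared core, is unchanged.

With nothing to anchor the size of this kind of change, the step in this assay from compound 1 to compound 3 is expected to be small, and may well fall within the scatter, a 1.4-fold lower number from compound 1 to compound 3 (0.15 log units; within the scatter) being the estimate. On that basis compound 3 is expected to give about 18000 nM, most likely between 6000 nM and 50000 nM.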

Compound 3, concentration for 50% growth inhibition: 8800 nM
Compound 3: the middle estimate sits 2.0-fold (0.31 log units) above what was measured, within the range that was stated.
By their numbers in this assay, from the lowest: compound 3; then compound 1; then compound 2.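

Phenyl in place of morpholin-4-yl on this carbonyl carbon gives, in this assay, a 2.9-fold lower number from compound 1 to compound 3 (0.46 log units; beyond the scatter), the first step of known size in the series. This shows that the position responds to the group it carries: the two groups have the same count of heavy atoms, yet the modest step lies beyond the scatter, with the benzoyloxy group on the shared core left unchanged. Nothing shown here accounts for the step, so it cannot be assigned to any one difference between the morpholin-4-yl and phenyl rings.

On these data alone, it remains open whether a piperidin-1-yl or a dimethylamino group on the same carbonyl carbon would stand with morpholin-4-yl or with phenyl, and whether a pyridin-4-yl or 4-chlorophenyl group would match phenyl. As far as these compounds go, it is also open whether the same exchange would give a step of similar size with a free hydroxyl or an acetyloxy group in place of the benzoyloxy group on the shared core.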